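Capping the hydroxy of compound 1 with a methyl

A few compounds are considered here, and "the series" means these few. Any claim that something is new, unique, unknown or untested is made for them only; others in the source may bear on it.

Measured so far:
compound 1 `N#Cc1c(Nc2ccc(O)cc2)sc2ccccc12` gives 25% in a functional assay on HUVEC cells (Homo sapiens), read by fluorescence and microscopy, with a stated time of 6 h, tested at 10 uM; a higher number here means a weaker effect of the compound at the concentration tested, a lower number a stronger effect
compound 2 `N#Cc1c(Nc2ccc([N+](=O)[O-])cc2)sc2ccccc12` gives 8%
compound 3 `COc1cc2sc(Nc3cccc(O)c3)c(C#N)c2cc1OC` gives 11%

Compound 1 stands highest of the three numbers, so it shows the weakest effect of the set; compound 3 lies lower beyond the scatter, and compound 2 lower still. Among the measured compounds shown here, the one measured step, a number 17 percentage points lower from compound 1 to compound 2 (beyond the scatter), replaces the hydroxy with nitro and lowers the number.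

Compound 4 `COc1ccc(Nc2sc3ccccc3c2C#N)cc1` differs from compound 1 by methyl in place of hydrogen on an oxygen on an aromatic ring. For the measured compounds named here, no measured step makes this same change. The step to compound 2 touches the same hydroxy but exchanges it for a different group, so it only hints that altering this position moves the number down. Going by the values given here, compound 3 keeps a hydroxy and adds two methoxy groups and gives a lower number than compound 1, but no single step connects the two. The expectation for compound 4 is therefore a small downward step, a number 8 percentage points lower from compound 1 to compound 4 (within the scatter), possibly within the scatter. Compound 4 is estimated at 17%, with a range from 5% to 35%.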

Compound 4, a percentage reported as activity, at one concentration (the size of the read-out at that concentration, not a potency): 57%
Estimate against measurement, compound 4: 40 percentage points below; the measured number lies above the stated range.
By their numbers in this assay, from the lowest: compounds 2 and 3 (each within the scatter of the next); then compound 1; then compound 4.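

In this assay, capping the hydroxy of compound 1 weakens the effect rather than strengthening it, with a number 32 percentage points higher from compound 1 to compound 4 (beyond the scatter), so the hydrogen on an oxygen on an aromatic ring cannot be exchanged for methyl without a large change in the number. Changing this group therefore does not move the number one way: nitro lowers it, with a number 17 percentage points lower from compound 1 to compound 2 (beyond the scatter), methoxy raises it, and the two replacements stand far apart, with a number 49 percentage points higher from compound 2 to compound 4 (beyond the scatter). No measurement at hand explains the difference between these groups.

From the compounds shown here alone, whether a longer chain on the same oxygen would raise the number further than methyl remains open. Also open, going by these compounds, is where an amine or a carboxylic acid in place of the hydroxy would fall relative to nitro and methoxy.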